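The source may report more compounds than this note shows. Statements on the series, on what has been measured and on what is new or still open speak of the compounds shown alone.

Measured compounds:
compound 1, `O=C(CSc1nc(Nc2ccccc2)c2ccccc2n1)Nc1ccc(Cl)cc1`, 12900 nM
compound 2, `O=C(CSc1nc(Nc2ccccc2)c2ccccc2n1)Nc1ccc(Cl)c(Cl)c1`, 12100 nM
compound 3, `C=CC(=O)Nc1cccc(NC(=O)CSc2nc(Nc3ccccc3Cl)c3ccccc3n2)c1`, 14400 nM

In a functional assay on PC-3 cells (Homo sapiens) for inhibition, read by MTT assay, with a stated time of 72 h (on this read-out higher numbers stand for weaker inhibition and lower numbers for stronger inhibition), compound 3 gives the highest of the three numbers, but its gaps to compound 1 and to compound 2 both lie within the usual scatter, so the three compounds show no difference that can be trusted. Compound 4 is `C=CC(=O)Nc1cccc(NC(=O)CSc2nc(Nc3cccc(Br)c3)c3ccccc3n2)c1`. It differs from compound 3 in one place: 3-bromophenyl in place of 2-chlorophenyl on a nitrogen on an aromatic ring. Within the data shown here, the only single-site step measured, a 1.1-fold lower number from compound 1 to compound 2 (0.03 log units; within the scatter), concerns a chloro added on the amide-side aromatic ring and changed nothing beyond the scatter; no measured pair varies the aryl on the aromatic-ring nitrogen, so nothing recorded speaks directly to this change. With every recorded number sitting close together, compound 4 is expected to stay in the same region, and the expected step of a 1.1-fold lower number from compound 3 to compound 4 (0.04 log units; within the scatter) is one within the scatter. Compound 4 is therefore estimated at 13000 nM, in a range from 6000 nM to 30000 nM.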

Compound 4, half-maximal inhibitory concentration: 15000 nM
The estimate for compound 4 lay 1.2-fold (0.06 log units) below the measured number; low and high end bracket the measured number.
By their numbers in this assay, from the lowest: compounds 2, 1, 3 and 4 (each within the scatter of the next).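

In this assay, among these compounds, the exchange of 2-chlorophenyl for 3-bromophenyl on a nitrogen on an aromatic ring gives a 1.0-fold higher number from compound 3 to compound 4 (0.02 log units; within the scatter) and is the first measured step at this position. Among the compounds shown here, the only earlier step, a 1.1-fold lower number from compound 1 to compound 2 (0.03 log units; within the scatter), concerned a chloro in place of hydrogen on an aromatic carbon, so it said nothing about this position. Here the halogen and its place on the phenyl ring changed together and the number stayed within the scatter, and no measurement on hand offers an explanation for this result.

The compounds shown leave open whether an amine or a carboxylic acid on this phenyl ring would carry the number beyond the scatter. They also leave open what a longer alkyl chain in place of the aryl group would do.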